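Adding a Chlorine to Compound 2

The source may report more compounds than this note shows. Statements on the series, on what has been measured and on what is new or still open speak of the compounds shown alone.

Compound 1 `O=C1Nc2ccccc2/C1=C\c1c(Cl)n(Cc2ccccc2)c2ccccc12` and compound 2 `O=C1Nc2ccccc2/C1=C\c1c(Cl)n(CCCc2ccccc2)c2ccccc12` share one core and differ only in the chain on the aromatic nitrogen. In a functional assay on cells (Cancer cell lines, Homo sapiens) for cytotoxicity, with a stated time of 48 h (on this read-out lower numbers stand for stronger inhibition of growth and higher numbers for weaker inhibition of growth), compound 1 gives 47900 nM, and compound 2 gives 75900 nM; the step of a 1.6-fold higher number from compound 1 to compound 2 (0.20 log units; within the scatter) means the two values lie within the scatter of each other, so compound 2 does not stand apart. Compound 3 `O=C1Nc2ccc(Cl)cc2/C1=C\c1c(Cl)n(CCCc2ccccc2)c2ccccc12` differs from compound 2 by chloro in place of hydrogen on an aromatic carbon. Among the compounds with values here, no measured step touches this change, so no direction is indicated, and the expected step is a 1.3-fold lower number from compound 2 to compound 3 (0.10 log units; within the scatter). Compound 3 is therefore estimated at 60000 nM, within 20000 nM to 150000 nM.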

Compound 3, concentration for total growth inhibition: 10200 nM
For compound 3 the middle estimate is 5.9-fold (0.77 log units) above the measured one; measured number outside the range, below it.
By their numbers in this assay, from the lowest: compound 3; then compounds 1 and 2 (each within the scatter of the next).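

In this assay, changing the chain on the aromatic nitrogen gave a step within the scatter, whereas chloro in place of hydrogen on an aromatic carbon gives a 7.4-fold lower number from compound 2 to compound 3 (0.87 log units; beyond the scatter). This shows that, with the chain of compound 2 in place, the growth-inhibition read-out responds to this single added atom on the shared core. Nothing measured here gives a reason for this drop. Still open, from the compounds shown here alone, is whether a fluoro, a methoxy or an amine at this position would give a similar step, and whether chloro would give one with the chain of compound 1.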